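Swapping the aryl on the triazole of compound 2

The compounds below may be only part of what the source reports. "The series", "measured", "known", "first", "only" and "open" are said of these compounds alone.

Compound 1 `COc1cc2c(cc1CCC(C)C)C(=O)C[C@@H](c1ccc(O)cc1)O2` is the shorter member of the pair; in a functional assay on PC-3 cells (Homo sapiens) for inhibition, read by sulforhodamine B assay, with a stated time of 48 h, tested at 50 uM (a higher number here means more inhibition of growth at the concentration tested, a lower number less inhibition of growth), compound 1 gives 78%. Compound 2 `COc1ccc([C@@H]2C/C(=N/OCc3cn(-c4ccc(O)cc4)nn3)c3cc(CC=C(C)C)c(OC)cc3O2)cc1` carries the longer arm ending in the triazole; in this assay compound 2 gives 64%, the lower of the two numbers, with compound 1 higher by a margin beyond the scatter. The two measured compounds differ in several places at once, so their gap cannot be tied to any single change. Compound 3 `COc1ccc([C@@H]2C/C(=N/OCc3cn(-c4cccnc4Cl)nn3)c3cc(CC=C(C)C)c(OC)cc3O2)cc1` is compound 2 altered in one place: 2-chloropyridin-3-yl in place of 4-hydroxyphenyl on an aromatic nitrogen. Within the data shown here, nothing measured so far isolates the group on the triazole nitrogen from the rest of the arm, so the size of this step is unknown; the expected step is a number 4 percentage points lower from compound 2 to compound 3 (within the scatter), within the scatter and leaning slightly downward. Compound 3 is therefore estimated to give 60% in this assay, with a range from 42% to 76%.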

Compound 3, percent growth inhibition at one concentration: 44%
The estimate for compound 3 lay 16 percentage points above the measured number, and the stated range covers the measured number.
By their numbers in this assay, from the lowest: compound 3; then compound 2; then compound 1.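

The aryl on the triazole nitrogen is not a silent part of the arm: in this assay the exchange of 4-hydroxyphenyl for 2-chloropyridin-3-yl reads a number 20 percentage points lower from compound 2 to compound 3 (beyond the scatter) and gives the first change tied to a single place in the series. The two groups have the same heavy-atom count, so the step does not come with any change in that count. The exchange removes the hydrogen-bond donor and brings in a ring nitrogen and a chlorine together, and no measurement at hand accounts for the step.

Which of these parts of the exchange carries the step stays open. A plain phenyl or an unsubstituted pyridinyl on the same triazole nitrogen would separate the loss of the hydroxyl from the arrival of the ring nitrogen and the chlorine.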